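Cytotoxicity notes: isobutyl in place of benzyl on compound 1

The source may hold more compounds than are shown below. What is called first, only, known or untested is meant among the compounds shown, and "the series" means these compounds.

Compound 1 `Cc1ccc(Cn2ccc3nc(-c4ccccc4)nc-3c2)cc1` is the reference point. In an ADME assay on MDBK cells (Bos taurus) for cytotoxicity (a higher number here means that more compound is tolerated, a lower number that less compound is tolerated), compound 1 gives > 100000 nM, which is a limit of the assay and not a number. Compound 3 `c1ccc(-c2nc3cc[nH]cc-3n2)cc1` likewise sits at a limit, giving > 100000 nM in this assay. Compound 2 `Brc1ccc(Cn2ccc3nc(-c4ccccc4)nc-3c2)cc1` gives 83000 nM in this assay. Among the measured compounds shown here, the one measured step, an at least 1.2-fold lower number from compound 1 to compound 2 (0.08 log units; that floor lies within the scatter), bromo in place of methyl on an aromatic carbon, has a floor that lies within the scatter, so it shows no clear movement. The evidence on the series is thin: the limit of > 100000 nM in this assay, at which 2 of the 3 values shown sit.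

Compound 4 `CC(C)CCn1ccc2nc(-c3ccccc3)nc-2c1` differs from compound 1 as follows: isobutyl in place of 4-methylphenyl on a saturated chain carbon bound to an aromatic nitrogen. For the measured compounds named here, no measured step covers this change; the step from compound 1 to compound 2 alters a substituent on the ring that now leaves, and is in any case within the scatter. Three values, two at the limit, give no reason to expect compound 4 to move. The step expected for compound 4 is a number no higher from compound 1 to compound 4 (the limit leaves the size open), nothing beyond the scatter. Compound 4 is therefore estimated at 100000 nM, with a range of 50000 nM to 300000 nM, most likely again reported as a limit.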

Compound 4, half-maximal cytotoxic concentration: > 100000 nM
Compound 4 gave a limit, no number; the forecaster's own chance of this, stated with the estimate: 60%; the middle value lies on the limit itself.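

The saturated chain carbon bound to an aromatic nitrogen now carries isobutyl, a group with no ring, and in this assay compound 4 gives > 100000 nM, which is a limit of the assay and not a number. Among the compounds shown here, the only readable step is an at least 1.2-fold higher number from compound 2 to compound 4 (0.08 log units; that floor lies within the scatter), which shows no clear movement, while the steps from compound 1 and compound 3 to compound 4 cannot be read, both ends being limits. Removing the aromatic ring from this position therefore produces no readable change, and the series stays largely uninformative: the limit of > 100000 nM in this assay, at which 3 of the 4 values shown sit.

Going by these compounds, whether an amine or a carboxylic acid at this position would bring the number off the limit remains open. Only compound 2 gives a number, 83000 nM, so no change shown yet moves the value beyond the scatter.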